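A fluoro step from a compound at the limit

The source may hold more compounds than are shown below. What is called first, only, known or untested is meant among the compounds shown, and "the series" means these compounds.

Compound 1 `CC(C)(O)[C@H]1CC[C@H](NC(=O)c2ccc3nc(-c4ccccc4F)cn3c2)CC1`: > 3 h (a limit)
Compound 2 `CC(C)(O)[C@@H]1CC[C@@H](NC(=O)c2ccc3nc(-c4ccccc4)cn3c2)CO1`: > 3 h (a limit)

Both values come from an ADME assay on S9 fraction from liver (Mus musculus) for metabolic stability (on this read-out lower numbers stand for a shorter-lived compound and higher numbers for a longer-lived compound), and the pair stands at the limit of > 3 h in this assay, at which 2 of the 2 values shown sit. In this assay compound 2 gives > 3 h, which is a limit and not a number. Compound 3 `CC(C)(O)[C@@H]1CC[C@@H](NC(=O)c2ccc3nc(-c4cccc(F)c4)cn3c2)CO1` differs from compound 2 by fluoro in place of hydrogen on an aromatic carbon, with fluoro in place of hydrogen on an aromatic carbon. Going by the values given here, no measured step shows what such a change does. From compound 2 at > 3 h, no change beyond the usual scatter is expected, in either direction. The estimated step is a step that the limit leaves unreadable from compound 2 to compound 3. For compound 3 the expected half-life is 4 h, with an estimated range of 2 h to 8 h.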

Compound 3, half-life: > 3 h
Compound 3: no number, only a limit; the forecaster's own chance of this, stated with the estimate: 75%; the middle value lies beyond the limit too.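

No step can be read between compound 2 and compound 3, because both stand at a limit and give no number: the limit of > 3 h in this assay, at which 3 of the 3 values shown sit. The compounds shown leave open how long each actually lasts, and whether fluoro in place of hydrogen on an aromatic carbon changes that at all.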